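A few compounds are considered here, and "the series" means these few. Any claim that something is new, unique, unknown or untested is made for them only; others in the source may bear on it.

Measured compounds:
- compound 1 `O=C(NOC[C@H](O)CO)c1cc2c(c(F)c1Nc1ccc(I)cc1F)OCC2` — 9.4 L/kg
- compound 2 `O=C(NOC[C@H](O)CO)c1cc2ccoc2c(F)c1Nc1ccc(I)cc1F` — "not determined" (no result reported)

The study looks at how widely a compound spreads through the body after dosing, measured in an ADME assay on the whole organism (strain Sprague-Dawley) for pharmacokinetics, with Rattus norvegicus as the target, at a dose of 2 mg/kg by the intravenous route; a lower number here means that more of the compound stays in the plasma, a higher number that more of the compound sits outside the plasma. Compound 1 gives 9.4 L/kg, a number that points to most of the compound sitting outside the plasma. Compound 2 shares the side chain of compound 1 but carries a different shared core; in this assay compound 2 gives "not determined" (no result reported), so there is nothing to place it against compound 1.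

Compound 3 `O=C(NOC(CO)CO)c1cc2ccoc2c(F)c1Nc1ccc(I)cc1F` keeps the core of compound 2 and differs only in how the side chain on the oxygen is joined: 2-hydroxy-1-(hydroxymethyl)ethyl in place of 2,3-dihydroxypropyl on an oxygen. The same atoms are present, the same count of hydrogen-bond donors and acceptors, and only the point of attachment moves. Within the data shown here, with no measured step between related pairs, the expected change in this assay is none beyond the usual scatter, and the only anchor is compound 1. On that basis compound 3 is estimated to give 8 L/kg in this assay, within a range of 3.5 L/kg to 18 L/kg.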

Compound 3, volume of distribution at steady state: 0.8 L/kg
Estimate against measurement, compound 3: 10-fold (1.00 log units) above; the measured number lies below the stated range.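

No new step can be read for compound 3: compound 2, which differs from it in one place, has no number in this assay, and compound 1 differs from it in both core and side chain. Nothing available explains the result. As far as these compounds go, what 2-hydroxy-1-(hydroxymethyl)ethyl in place of 2,3-dihydroxypropyl does on its own remains open.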